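The compounds below may be only part of what the source reports. "The series", "measured", "known", "first", "only" and "open" are said of these compounds alone.

Measured so far in an assay on isolated protein (Cavia porcellus) with Sigma non-opioid intracellular receptor 1 (Homo sapiens) as the target, read by radioligand binding; on this read-out higher numbers stand for weaker inhibition and lower numbers for stronger inhibition:
compound 1, `CN(C)CCCCCCOc1ccc2oc(-c3ccccc3)cc(=O)c2c1`, 335 nM
compound 2, `COc1cccc(-c2cc(=O)c3cc(OCCCCCCN4CCC(O)CC4)ccc3o2)c1`, 111 nM

Compound 2 holds the lower of the two numbers, and its gap to compound 1 lies beyond the usual scatter of the read-out. Compound 3, `O=c1cc(C2CCCCC2)oc2ccc(OCCCCCCN3CCC(O)CC3)cc12`, is reached from compound 2 by cyclohexyl in place of 3-methoxyphenyl on an aromatic carbon. Within the data shown here, no measured pair in this set carries a change of that kind, so the step is only expected to be modest, a 1.8-fold higher number from compound 2 to compound 3 (0.26 log units; within the scatter) in this assay, tending toward a somewhat weaker number. Compound 3 is accordingly expected to give 200 nM, within a range from 70 nM to 600 nM.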

Compound 3, half-maximal inhibitory concentration: 46 nM
For compound 3 the middle estimate is 4.3-fold (0.64 log units) above the measured one; the whole stated range lies above it.
By their numbers in this assay, from the lowest: compound 3; then compound 2; then compound 1.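

In this assay, cyclohexyl in place of 3-methoxyphenyl next to the ring oxygen gives a 2.4-fold lower number from compound 2 to compound 3 (0.38 log units; beyond the scatter). This position therefore needs no aromatic ring for binding at this level, and the hydrogen-bond acceptor that leaves with 3-methoxyphenyl is not required either. No available evidence explains the step.

As far as these compounds go, whether a cyclopentyl ring or an open tert-butyl group at this position would do as well remains open. So does whether cyclohexyl would give a similar step with the dimethylamino end of compound 1.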